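The source may hold more compounds than are shown below. What is called first, only, known or untested is meant among the compounds shown, and "the series" means these compounds.

In a functional assay on MCF7 cells (Homo sapiens) for antiproliferative activity, read by CellTiter-Glo, with a stated time of 5 days (a lower number here means a stronger inhibitor, a higher number a weaker inhibitor), compound 1 `CC/C(=C(/c1ccc(/C=C/C(=O)O)cc1)c1ccc2c(cnn2C)c1)c1ccc(F)cc1Cl` gives 81 nM while compound 2 `CC/C(=C(/c1ccc(/C=C/C(=O)O)cc1)c1ccc2c(cnn2C)c1)c1ccccc1` gives 300 nM and compound 3 `CC/C(=C(/c1ccc(/C=C/C(=O)O)cc1)c1ccc2nccn2c1)c1ccccc1` gives 170 nM which lies within the scatter of compound 2. Compound 4 `CC/C(=C(/c1ccc(/C=C/C(=O)O)cc1)c1ccc2nncn2c1)c1ccccc1` differs from compound 3 by one swap on a double-bonded chain carbon bound to an aromatic carbon and a double-bonded chain carbon (a group of 9 heavy atoms (6 carbon, 3 nitrogen; one five-membered aromatic ring with 3 hetero atoms, one six-membered aromatic ring with 1 hetero atom) in place of a group of 9 heavy atoms (7 carbon, 2 nitrogen; one five-membered aromatic ring with 2 hetero atoms, one six-membered aromatic ring with 1 hetero atom), on a double-bonded chain carbon bound to an aromatic carbon and a double-bonded chain carbon). Within the data shown here, the only measured swap at that place gave a small step (a 1.8-fold lower number from compound 2 to compound 3 (0.25 log units; within the scatter)). The swap of phenyl in place of 2-chloro-4-fluorophenyl gave a larger one (a 3.7-fold higher number from compound 1 to compound 2 (0.57 log units; beyond the scatter)) but sits at a different place, so it bears less on this change. No step beyond the scatter is therefore expected, and the estimate means only a slight move (a 1.3-fold higher number from compound 3 to compound 4 (0.11 log units; within the scatter)). Compound 4 is expected at 220 nM in this assay with an estimated range from 90 nM to 550 nM for repeated measurements.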

Compound 4, half-maximal inhibitory concentration: > 500 nM
Compound 4: only a limit was reported; the forecaster's own chance of this, stated with the estimate: 3%; middle value at least 2.2-fold (0.35 log units) away from the limit.
By their numbers in this assay, from the lowest: compound 1; then compounds 3 and 2 (each within the scatter of the next). At a limit, above all of these: compound 4.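

In this assay, compound 4 is reported only as a limit, not as a number: the limit of > 500 nM in this assay, at which 1 of the 4 values shown sits. Among these compounds, exchanging one carbon for nitrogen in the group gives an at least 2.9-fold higher number from compound 3 to compound 4 (0.46 log units; beyond the scatter), so this place responds to a change that keeps the ring sizes and the heavy-atom count, which the earlier compounds did not show. Against the group of compound 2, the change gives an at least 1.6-fold higher number from compound 2 to compound 4 (0.22 log units; that floor lies within the scatter), and that floor alone separates nothing.

Going by these compounds, how far the true value of compound 4 lies past its limit stays open. So does whether an amino group on its five-membered ring would change the result.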